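Amine side-chain swap and cytotoxicity: compound 3 to compound 4

The source may report more compounds than this note shows. Statements on the series, on what has been measured and on what is new or still open speak of the compounds shown alone.

Compound 1 `CN1CCN(CCNCc2cn(-c3ccc(C(F)(F)F)cc3)nc2-c2ccc(C(F)(F)F)cc2)CC1` and compound 2 `CCCN1CCC(CNCc2cn(-c3ccc(C(F)(F)F)cc3)nc2-c2ccc(C(F)(F)F)cc2)CC1` share one core. In an ADME assay on Huh-7 cells (Homo sapiens) for cytotoxicity (on this read-out lower numbers stand for higher toxicity in this test and higher numbers for lower toxicity in this test), compound 1 gives 1500 nM and compound 2 gives 1200 nM. The structural change between them is 1-propylpiperidin-4-yl in place of (4-methylpiperazin-1-yl)methyl on a saturated chain carbon bound to an amine nitrogen, and it made a 1.3-fold lower number from compound 1 to compound 2 (0.10 log units; within the scatter). Compound 3 `CN1CCN(CCNCc2cn(-c3ccc([N+](=O)[O-])cc3)nc2-c2ccc(Cl)cc2)CC1` carries a different core; the difference between the two cores is not broken down here. In this assay compound 3 gives 5000 nM, the highest of the three numbers, with gaps to compound 1 and compound 2 that lie beyond the scatter.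

Compound 4 `CCCN1CCC(CNCc2cn(-c3ccc([N+](=O)[O-])cc3)nc2-c2ccc(Cl)cc2)CC1` has not been measured in this assay. It differs from compound 3 by 1-propylpiperidin-4-yl in place of (4-methylpiperazin-1-yl)methyl on a saturated chain carbon bound to an amine nitrogen, the same change that was made from compound 1 to compound 2, at the same place. The step from compound 3 to compound 4 is expected to be small, a 1.3-fold lower number from compound 3 to compound 4 (0.10 log units; within the scatter), because the matching step a 1.3-fold lower number from compound 1 to compound 2 (0.10 log units; within the scatter) stayed within the scatter. On that basis compound 4 is estimated at 4000 nM in this assay, with a likely range from 2000 nM to 9000 nM.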

Compound 4, half-maximal cytotoxic concentration: 11000 nM
Estimate against measurement, compound 4: 2.8-fold (0.44 log units) below; the measured number lies above the stated range.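

In this assay, putting 1-propylpiperidin-4-yl in place of (4-methylpiperazin-1-yl)methyl gives a 2.2-fold higher number from compound 3 to compound 4 (0.34 log units; beyond the scatter), a move towards lower toxicity in this test on the core of compound 3. The change does not carry over with the same size from the core of compound 1 to the core of compound 3, so a step read on one of these cores is a poor guide to the other: the same change on two cores in this assay, a 1.3-fold lower number (0.10 log units; within the scatter) from compound 1 to compound 2 and a 2.2-fold higher number (0.34 log units; beyond the scatter) from compound 3 to compound 4, 2.8-fold (0.44 log units) apart, beyond the scatter of two such steps This rests on a single pair per core, so it shows a core dependence for these four compounds only; it does not show which feature of the cores is responsible, or whether the same holds on any other core.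

Open, as far as these compounds go, is which of the differences between the two cores goes with this gap, for instance whether a core bearing one trifluoromethyl group and one nitro group would follow compound 1 or compound 3. Also open, from the compounds shown here alone, is how a morpholine side chain, or an ethyl in place of the propyl on the piperidine, would behave on either core.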